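Swapping a Benzyl Substituent in a Cytotoxicity Screen

A few compounds are considered here, and "the series" means these few. Any claim that something is new, unique, unknown or untested is made for them only; others in the source may bear on it.

Compound 2 `CCOC(=O)c1cnc(N2CCN(Cc3cc(F)cc(F)c3)CC2)nc1Oc1c(C)cc(-c2ccc(C#N)cc2)cc1C` carries a 3,5-difluorophenyl group on a saturated chain carbon bound to an amine nitrogen in a ring. In an ADME assay on MT4 cells (Homo sapiens) for cytotoxicity, read by MTT assay, with a stated time of 4 days (on this read-out lower numbers stand for higher toxicity in this test and higher numbers for lower toxicity in this test), compound 2 gives > 125000 nM, which is a limit of the assay and not a number. Its closest relative, compound 1 `CCOC(=O)c1cnc(N2CCN(Cc3ccccc3C(F)(F)F)CC2)nc1Oc1c(C)cc(-c2ccc(C#N)cc2)cc1C`, differs only in the group on that carbon. In this assay compound 1 gives > 125000 nM, again a limit of the assay rather than a number. The step that the two limits leave unreadable from compound 1 to compound 2 therefore stays unreadable, as shown by the limit of > 125000 nM in this assay, at which 2 of the 2 values shown sit.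

Compound 3 `CCOC(=O)c1cnc(N2CCN(Cc3cccc(OC)c3)CC2)nc1Oc1c(C)cc(-c2ccc(C#N)cc2)cc1C` has not yet been measured. The change from compound 2 is 3-methoxyphenyl in place of 3,5-difluorophenyl on a saturated chain carbon bound to an amine nitrogen in a ring. For the measured compounds named here, the only measured step that bears on this position is the one from compound 1 to compound 2, and its size cannot be read, since both compounds sit at the same limit. With no readable step in hand, no movement beyond the scatter is expected, and compound 3 is expected to show a step that the limit leaves unreadable from compound 2 to compound 3 in this assay. Compound 3 is therefore estimated at 150000 nM, with a range from 60000 nM to 400000 nM, and most likely it will again be reported only as a limit.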

Compound 3, half-maximal cytotoxic concentration: > 125000 nM
Compound 3 ended at the assay's limit; the forecaster's own chance of this, stated with the estimate: 85%; the middle value is on the limit's open side.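

In this assay the steps among compound 1, compound 2 and compound 3 cannot be read, since each result is a limit of the assay and not a number: the limit of > 125000 nM in this assay, at which 3 of the 3 values shown sit.

Where the true cytotoxic concentration of each compound lies, and whether swapping these benzyl groups changes it at all, stays open.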